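A few compounds are considered here, and "the series" means these few. Any claim that something is new, unique, unknown or untested is made for them only; others in the source may bear on it.

Measured so far:
- compound 1, `CC(C)c1onc(-c2c(Cl)cccc2Cl)c1COc1ccc(-c2nc3ccc(C(=O)O)cc3n2-c2ccc(F)cc2)cc1`: 15.1 nM
- compound 2, `CC(C)c1onc(-c2c(Cl)cccc2Cl)c1COc1ccc(-c2nc3ccc(C(=O)O)cc3n2C2CCC2)cc1`: "not determined" (no result reported)
- compound 3, `CC(C)c1onc(-c2c(Cl)cccc2Cl)c1COc1ccc(-c2nc3ccc(C(=O)O)cc3n2C2CCCCCC2)cc1`: 113 nM

The read-out throughout is an assay on isolated protein for agonist activity at Bile acid receptor (Homo sapiens), read by TR-FRET; a lower number here means that less compound is needed, a higher number that more compound is needed for the effect. Among the compounds with values here, compound 3 gives the highest of the two numbers available; the nearest is compound 1, and the only single-change step in the set runs between them: a 7.5-fold higher number from compound 1 to compound 3 (0.87 log units; beyond the scatter). Compound 2 carries a cyclobutyl on the same aromatic nitrogen but has no number, so it cannot be placed.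

Compound 4, `CC(C)c1onc(-c2c(Cl)cccc2Cl)c1COc1ccc(-c2nc3ccc(C(=O)O)cc3n2Cc2ccc(F)cc2)cc1`, differs from compound 3 in one place: 4-fluorobenzyl in place of cycloheptyl on an aromatic nitrogen. The change returns an aromatic ring with fluorine to the aromatic nitrogen, now through a one-carbon link, where compound 1 has it attached directly. Within the data shown here, the one relevant step is the one from compound 1 to compound 3, which was beyond the scatter, and the present change partly reverses it. The expectation is therefore a lower number than compound 3 in this assay, though not necessarily all the way back to compound 1; the estimated step is a 3.2-fold lower number from compound 3 to compound 4 (0.51 log units; beyond the scatter). For compound 4 the estimate in this assay is 35 nM, with a range from 12 nM to 110 nM.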

Compound 4, half-maximal effective concentration: 105 nM
Estimate against measurement, compound 4: 3.0-fold (0.48 log units) below; low and high end bracket the measured number.
By their numbers in this assay, from the lowest: compound 1; then compounds 4 and 3 (each within the scatter of the next).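

In this assay, bringing back a fluorinated aromatic ring through a one-carbon link does not recover the number of the directly attached ring: the step is a 7.0-fold higher number from compound 1 to compound 4 (0.84 log units; beyond the scatter), on the same scale as a 7.5-fold higher number from compound 1 to compound 3 (0.87 log units; beyond the scatter). Replacing the saturated ring with 4-fluorobenzyl gives a 1.1-fold lower number from compound 3 to compound 4 (0.03 log units; within the scatter), so cycloheptyl and 4-fluorobenzyl cannot be told apart at this position, and among the groups with numbers only the 4-fluorophenyl of compound 1 stands apart. Nothing available explains this result.

Still open, from the compounds shown here alone, is whether plain phenyl on this nitrogen would read like 4-fluorophenyl, and how a longer chain such as 2-phenylethyl would read. Steps involving the cyclobutyl of compound 2 cannot be read, so the effect of saturated ring size also stays open.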